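The source may hold more compounds than are shown below. What is called first, only, known or untested is meant among the compounds shown, and "the series" means these compounds.

Measured so far in an ADME assay on microsomes from liver (Homo sapiens) for metabolic stability; on this read-out lower numbers stand for a shorter-lived compound and higher numbers for a longer-lived compound:
compound 1 `CC(C)C(c1ccc(-c2ccc3cccc(F)c3c2)[nH]c1=O)N1CCCCS1(=O)=O`: 0.373 h
compound 2 `CC(C)C(Nc1nnc[nH]1)c1ccc(-c2ccc3cccc(F)c3c2)[nH]c1=O`: > 3 h; for compound 2 this is a limit of the assay, not a number
compound 3 `CC(C)C(c1ncco1)c1ccc(-c2ccc3cccc(F)c3c2)[nH]c1=O`: 0.178 h

Compound 3 holds the lowest of the two numbers, the gap to its nearest neighbour being a 2.1-fold lower number from compound 1 to compound 3 (0.32 log units; beyond the scatter).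

Compound 4 `CC(C)C(c1ccc(-c2ccc3cccc(F)c3c2)[nH]c1=O)N1CCN/C1=N\C#N` differs from compound 3 by a group of 8 heavy atoms (4 carbon, 4 nitrogen; one five-membered non-aromatic ring with 2 hetero atoms) in place of a group of 5 heavy atoms (3 carbon, 1 nitrogen, 1 oxygen; one five-membered aromatic ring with 2 hetero atoms), on a saturated chain carbon bound to an aromatic carbon and a saturated chain carbon. Among the compounds with values here, two measured steps bear on this change, a 2.1-fold lower number from compound 1 to compound 3 (0.32 log units; beyond the scatter) and an at least 16-fold lower number from compound 2 to compound 3 (1.22 log units; beyond the scatter); in both, the 1,3-oxazol-2-yl end carries the lower number, and the larger one is bounded only by the limit of > 3 h in this assay, at which 1 of the 3 values shown sits. Moving back to a non-aromatic ring with one hydrogen-bond donor, an increase in this assay beyond the scatter is expected, about a 3.4-fold higher number from compound 3 to compound 4 (0.53 log units; beyond the scatter). Compound 4 is therefore estimated at 0.6 h, with a range from 0.25 h to 1.6 h.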

Compound 4, half-life: 0.632 h
For compound 4 the middle estimate is 1.1-fold (0.02 log units) below the measured one; the range from low to high includes it.
By their numbers in this assay, from the lowest: compound 3; then compounds 1 and 4 (each within the scatter of the next). At a limit, above all of these: compound 2.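

At this saturated chain carbon, two non-aromatic rings of different make-up are not separated in this assay, with a 1.7-fold higher number from compound 1 to compound 4 (0.23 log units; within the scatter). The new five-membered non-aromatic ring is clearly apart from 1,3-oxazol-2-yl, with a 3.6-fold higher number from compound 3 to compound 4 (0.55 log units; beyond the scatter). It does not match (4H-1,2,4-triazol-3-yl)amino, with an at least 4.7-fold lower number from compound 2 to compound 4 (0.67 log units; beyond the scatter), and the size of that step is bounded only: the limit of > 3 h in this assay, at which 1 of the 4 values shown sits.

Where a simple amine or a carboxylic acid would fall at this place remains open. So does how far the value of compound 2 lies past its limit.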